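Lengthening the ester chain: methoxy to butoxy

The source may hold more compounds than are shown below. What is called first, only, known or untested is meant among the compounds shown, and "the series" means these compounds.

Of the compounds shown here, two anchor the series so far. In a functional assay on RAW264.7 cells (Mus musculus) for inhibition (on this read-out higher numbers stand for weaker inhibition and lower numbers for stronger inhibition), compound 1 (`CCOC(=O)C1=CCCCC1S(=O)(=O)Nc1cc(F)c(F)cc1F`) gives 30 nM and compound 2 (`COC(=O)C1=CCCCC1S(=O)(=O)Nc1ccc(F)cc1F`) gives 57 nM. These two numbers lie within the scatter of each other, so compound 2 stands level with compound 1 on the present data.

The next compound to read is compound 3 (`CCCCOC(=O)C1=CCCCC1S(=O)(=O)Nc1ccc(F)cc1F`). It keeps the core of compound 2 and carries propyl in place of hydrogen on a saturated chain carbon bound to an oxygen next to a carbonyl group, which amounts to methoxy to butoxy (propyl in place of hydrogen on a saturated chain carbon bound to an oxygen next to a carbonyl group).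

Going by the values given here, no measured pair differs in one place only, so the effect of this change in this assay has no direct precedent. The starting point is therefore compound 2 at 57 nM, with a wide margin on either side. A small move toward weaker inhibition is expected, not clearly beyond the scatter. The estimated step is a 1.4-fold higher number from compound 2 to compound 3 (0.15 log units; within the scatter). For compound 3 the expected value is 80 nM, with an estimated range of 25 nM to 260 nM.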

Compound 3, half-maximal inhibitory concentration: 140 nM
Compound 3: middle estimate off by 1.8-fold (0.24 log units), on the low side, within the range that was stated.
By their numbers in this assay, from the lowest: compounds 1 and 2 (each within the scatter of the next); then compound 3.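

In this assay, methoxy to butoxy gives the series its first step between compounds that differ in one place: a 2.5-fold higher number from compound 2 to compound 3 (0.39 log units; beyond the scatter). This shows that the ester chain is not a silent position, since propyl in place of hydrogen on a saturated chain carbon bound to an oxygen next to a carbonyl group weakens inhibition by more than the scatter, though only modestly, while the rest of compound 2 stays unchanged. Nothing at hand accounts for this loss, and the step stands as an observation only.

As far as these compounds go, with only methoxy and butoxy to compare on this core, the shape of the trend remains open: ethoxy or propoxy could show whether the loss builds gradually with chain length or appears at one point, and hexyloxy could show whether it continues. Also open, from the compounds shown here alone, is whether the ester itself can be replaced on the core of compound 2, for example by a carboxylic acid or an amide, and whether a branched group such as isopropoxy would behave like the straight chains.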